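A few compounds are considered here, and "the series" means these few. Any claim that something is new, unique, unknown or untested is made for them only; others in the source may bear on it.

In a functional assay on MDA-MB-231 cells (Homo sapiens) for inhibition, read by CCK-8 assay and cell counting, with a stated time of 2 days (on this read-out higher numbers stand for weaker inhibition and lower numbers for stronger inhibition), compound 1 (`O=C(/C=C/c1cccs1)c1ccccc1OCC1CO1`) gives 17900 nM and compound 2 (`O=C(/C=C/c1cccs1)c1cccc(OCC2CO2)c1`) gives 15400 nM while compound 3 (`O=C(/C=C/c1cccs1)c1ccc(OCC2CO2)cc1`) gives 28300 nM on the same read-out. All three numbers sit within the usual scatter of one another, so compound 3 cannot be separated from the other two. Compound 4 (`O=C(/C=C/c1ccsc1)c1ccc(OCC2CO2)cc1`) differs from compound 3 in one place (thiophen-3-yl in place of thiophen-2-yl on a double-bonded chain carbon bound to a double-bonded chain carbon): it carries thiophen-3-yl in place of thiophen-2-yl on a double-bonded chain carbon bound to a double-bonded chain carbon. Among the measured compounds shown here, no measured pair shows this swap, so the expectation in this assay is for no step beyond the scatter. The estimated change is small (a 1.2-fold lower number from compound 3 to compound 4 (0.07 log units; within the scatter)). Compound 4 is expected at 24000 nM (estimated range 11000 nM to 50000 nM).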

Compound 4, half-maximal inhibitory concentration: 11100 nM
For compound 4 the middle estimate is 2.2-fold (0.33 log units) above the measured one, within the range that was stated.
By their numbers in this assay, from the lowest: compounds 4, 2, 1 and 3 (each within the scatter of the next, the first and the last beyond it).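

Swapping thiophen-2-yl for thiophen-3-yl on the double-bonded chain carbon gives, in this assay, a 2.5-fold lower number from compound 3 to compound 4 (0.41 log units; beyond the scatter), so this place responds to a change that only alters how the same ring is joined to the chain. Among the compounds here, this is the only listed one-place step, and it clears the usual scatter, though modestly. Nothing available explains the step.

As far as these compounds go, it remains open whether the same swap would give a similar step on the cores of compound 1 and compound 2. From the compounds shown here alone, how a furan or pyridine ring would compare at this place is also open.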